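A Halogen Swap on the Fused Ring of Compound 2

The source may hold more compounds than are shown below. What is called first, only, known or untested is meant among the compounds shown, and "the series" means these compounds.

Compound 2, `O=C(Nc1ccc(-c2n[nH]c(=O)c3c2CCCC3)cc1)N1Cc2ccc(F)cc2C1`, was tested in an assay on isolated protein for inhibition of Rho-associated protein kinase 2 (Homo sapiens), read by HTRF and 33P incorporation, in the presence of a further agent that is not named here (on this read-out lower numbers stand for stronger inhibition and higher numbers for weaker inhibition), where compound 2 gives 2.4 nM. Among the measured compounds shown here, its only measured companion is compound 1, `O=C(Nc1ccc(-c2n[nH]c(=O)c3c2CCCC3)cc1)N1Cc2ccccc2C1`; in this assay compound 1 gives 20 nM. Compound 2 therefore holds the lowest of the two numbers, and the step of an 8.3-fold lower number from compound 1 to compound 2 (0.92 log units; beyond the scatter) separates them by more than the usual scatter: a fluoro entering on an aromatic carbon of the fused ring brought the number down noticeably.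

Compound 3, `O=C(Nc1ccc(-c2n[nH]c(=O)c3c2CCCC3)cc1)N1Cc2ccc(Cl)cc2C1`, makes one further change: chloro in place of fluoro on an aromatic carbon. For the measured compounds named here, no measured step exchanges one halogen for another, so the only guidance comes from the step from compound 1 to compound 2, which showed that this carbon of the fused ring accepts a small substituent without loss. A chloro enters at the same place and is likewise a single heavy atom, so no shift beyond the scatter is expected in this assay. For compound 3 the expected value is 3 nM, within 1 nM to 10 nM. The step this estimate implies, a 1.3-fold higher number from compound 2 to compound 3 (0.10 log units; within the scatter), is expected to stay inside the usual scatter.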

Compound 3, inhibition constant: 6.5 nM
Compound 3: the middle estimate sits 2.2-fold (0.34 log units) below what was measured; measured number inside the range.
By their numbers in this assay, from the lowest: compound 2; then compound 3; then compound 1.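

The halogen at this position makes a real difference. Fluoro and chloro each add a single heavy atom and neither counts as a hydrogen-bond donor or acceptor, yet in this assay the exchange gives (a 2.7-fold higher number from compound 2 to compound 3 (0.43 log units; beyond the scatter)), so counts of this kind do not tell the two groups apart. The gain over hydrogen survives the exchange (a 3.1-fold lower number from compound 1 to compound 3 (0.49 log units; beyond the scatter)), which means that among these three compounds, both halogens give a lower number than hydrogen and fluoro gives the lowest; nothing available here accounts for the gap between the two halogens.

The compounds shown leave open how far this order extends, for instance whether a bromo on the same aromatic carbon would continue it, or whether a methoxy or an amine there would keep any of the gain over hydrogen. They also leave open whether fluoro and chloro would rank the same way on the other aromatic carbons of this ring, or on a different core.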